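Swapping a Pyridine for Chlorophenyl at the Amide

The source may hold more compounds than are shown below. What is called first, only, known or untested is meant among the compounds shown, and "the series" means these compounds.

Measured so far:
- Compound 1, `Cc1ccc(S(=O)(=O)NCc2ccc(CNC(=O)c3ccncc3)cc2)cc1`: 10 nM
- Compound 2, `O=C(NCc1ccc(CNS(=O)(=O)c2ccccc2)cc1)c1ccncc1`: 10 nM
- Compound 3, `Cc1ccc(S(=O)(=O)NCc2ccc(CNC(=O)c3ccccc3F)cc2)cc1`: 1000 nM

All three compounds were tested in an assay on MDA-MB-231 cells for binding affinity to C-X-C chemokine receptor type 4 (Homo sapiens), read by immunofluorescence and microscopy, with stated times of 10 min and 30 min; on this read-out higher numbers stand for an effect only at larger amounts of compound and lower numbers for an effect already at smaller amounts. Compound 2 stands level with compound 1 at the digits shown, and the two together give the lowest numbers of the three; compound 3 stands far from them, which the step of a 100-fold higher number from compound 1 to compound 3 (2.00 log units; beyond the scatter) makes plain. The other measured step, no change at the digits printed from compound 1 to compound 2 (within the scatter), shows that the exchange at the sulfonamide end made no difference beyond the scatter.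

The unmeasured compound 4, `O=C(NCc1ccc(CNS(=O)(=O)c2ccccc2)cc1)c1cccc(Cl)c1`, is reached from compound 2 by a single change: 3-chlorophenyl in place of pyridin-4-yl on a carbonyl carbon. Among the compounds with values here, of the two measured steps, only the one from compound 1 to compound 3 bears on this change, since it also replaces pyridin-4-yl on the carbonyl carbon by a ring of carbon only, and it was large. Within the data shown here, the chlorine of compound 4 sits at a different ring position than the fluorine of compound 3, and no measured compound tells how much that matters, so the size is uncertain.

A step of roughly a 50-fold higher number from compound 2 to compound 4 (1.70 log units; beyond the scatter) is therefore expected, towards a higher number. Compound 4 is estimated at 500 nM, with a range from 100 nM to 3000 nM.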

Compound 4, effective concentration (reported as EC, without a stated level of effect): 1000 nM
Compound 4: middle estimate off by 2.0-fold (0.30 log units), on the low side; the range from low to high includes it.
By their numbers in this assay, from the lowest: compounds 1 and 2 (each within the scatter of the next); then compounds 3 and 4 (each within the scatter of the next).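

In this assay the step of a 100-fold higher number from compound 2 to compound 4 (2.00 log units; beyond the scatter) matches in size the step of a 100-fold higher number from compound 1 to compound 3 (2.00 log units; beyond the scatter) and so extends the earlier finding: the large rise now appears with two different carbon-only rings on this carbonyl carbon, one bearing fluorine and the other chlorine, and both with and without the methyl on the sulfonamide's aromatic ring. Among these four compounds, the low numbers therefore occur only with pyridin-4-yl on the carbonyl carbon, a pattern that no compound shown goes against. Nothing given here explains why this exchange raises the number so much.

The change removes the ring nitrogen and adds a chlorine in a single step, so the compounds shown cannot separate the two, and they do not show whether the nitrogen's place in the ring matters. An unsubstituted phenyl ring on the carbonyl carbon would test the exchange without a halogen, while pyridin-3-yl or pyridin-2-yl would keep the nitrogen but move it to a different place in the ring.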